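The source may hold more compounds than are shown below. What is called first, only, known or untested is meant among the compounds shown, and "the series" means these compounds.

Compounds measured so far:

Compound 1 `O=C(CSc1nnc(-c2ccncc2)o1)N/N=C/c1ccc(Br)cc1` – 24500 nM
Compound 2 `O=C(CSc1nnc(-c2ccncc2)o1)N/N=C/c1ccc(O)cc1` – 7940 nM
Compound 3 `O=C(CSc1nnc(-c2ccncc2)o1)N/N=C/c1ccccc1[N+](=O)[O-]` – 41600 nM

In a functional assay on BGC-823 cells (Homo sapiens) for cytotoxicity, read by MTT assay, with a stated time of 48 h (a lower number here means a stronger inhibitor, a higher number a weaker inhibitor), compound 2 gives 7940 nM, the lowest of the three numbers; compound 1 stands a 3.1-fold lower number from compound 1 to compound 2 (0.49 log units; beyond the scatter) away, and compound 3 further still at a 5.2-fold higher number from compound 2 to compound 3 (0.72 log units; beyond the scatter). Compound 4 `O=C(CSc1nnc(-c2ccncc2)o1)N/N=C/c1cc(Cl)ccc1O` has not been measured. It differs from compound 2 in one place: 5-chloro-2-hydroxyphenyl in place of 4-hydroxyphenyl on a carbon with a double bond to nitrogen. For the measured compounds named here, two measured steps bear on this. The step of a 3.1-fold lower number from compound 1 to compound 2 (0.49 log units; beyond the scatter) shows that replacing bromo with hydroxy on the aromatic ring lowered the number, and the step of a 5.2-fold higher number from compound 2 to compound 3 (0.72 log units; beyond the scatter) shows that exchanging 4-hydroxyphenyl for 2-nitrophenyl raised it. Going by the values given here, compound 4 keeps a hydroxy group, moved, and gains a chlorine, so the change is partly like both steps and no single measured step matches it. The expected outcome is a small step, a 1.4-fold higher number from compound 2 to compound 4 (0.14 log units; within the scatter), in this assay, most likely within the scatter or slightly higher. Compound 4 is therefore estimated at 11000 nM, with a range from 4000 nM to 32000 nM.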

Compound 4, half-maximal inhibitory concentration: 5470 nM
Beside the measured number, compound 4's estimate is 2.0-fold (0.30 log units) above it, and the stated range covers the measured number.
By their numbers in this assay, from the lowest: compounds 4 and 2 (each within the scatter of the next); then compounds 1 and 3 (each within the scatter of the next).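

In this assay the step to 5-chloro-2-hydroxyphenyl gives a 1.5-fold lower number from compound 2 to compound 4 (0.16 log units; within the scatter) and so stays within the scatter, which shows that this place on the carbon with a double bond to nitrogen accepts a hydroxy-bearing ring with an added chlorine and a different substitution pattern without a clear change. The other two steps, a 7.6-fold lower number from compound 3 to compound 4 (0.88 log units; beyond the scatter) and a 4.5-fold lower number from compound 1 to compound 4 (0.65 log units; beyond the scatter), both lie beyond the scatter, so among these four compounds the two rings carrying a hydroxy group sit together at the low end, with no compound going against this. No measurement shown explains this grouping.

On these data alone, the chlorine and the new hydroxy placement arrive in a single step, so their separate contributions stay open. As far as these compounds go, how an amine or a carboxylic acid in place of the hydroxy would behave here also remains open.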